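Amino in place of arylthio on the exchanger inhibitor core

The source may report more compounds than this note shows. Statements on the series, on what has been measured and on what is new or still open speak of the compounds shown alone.

Compound 3 `Cc1cc(Sc2ccc(Cl)cc2)c(S(C)(=O)=O)cc1C(=O)N=C(N)N` is tested in a functional assay for inhibition of sodium/hydrogen exchanger (Oryctolagus cuniculus) (a lower number here means a stronger inhibitor, a higher number a weaker inhibitor), where compound 3 gives 19 nM. Among the three measured compounds it holds the second highest number: compound 2 `Cc1cc(C2CCCCC2)c(S(C)(=O)=O)cc1C(=O)N=C(N)N`, with 22 nM, lies within the scatter of it, while compound 1 `CCc1cc(C)c(C(=O)N=C(N)N)cc1S(C)(=O)=O`, with 4.8 nM, sits clearly lower. Compound 4 `Cc1cc(N)c(S(C)(=O)=O)cc1C(=O)N=C(N)N` arises from compound 3 by amino in place of (4-chlorophenyl)sulfanyl on an aromatic carbon. Among the compounds with values here, two measured steps bear on this change: a 4.0-fold higher number from compound 1 to compound 3 (0.60 log units; beyond the scatter) and a 1.2-fold lower number from compound 2 to compound 3 (0.06 log units; within the scatter). Both larger groups in place of ethyl raised the number modestly, so taking the large group away again may return part of the way toward compound 1. Compound 4 is therefore expected to show a modestly lower number, a step of a 1.9-fold lower number from compound 3 to compound 4 (0.28 log units; within the scatter). The estimate for compound 4 is 10 nM, with a range from 3 nM to 35 nM.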

Compound 4, half-maximal inhibitory concentration: 16 nM
Beside the measured number, compound 4's estimate is 1.6-fold (0.20 log units) below it, and the stated range covers the measured number.
By their numbers in this assay, from the lowest: compound 1; then compounds 4, 3 and 2 (each within the scatter of the next).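

In this assay, the position ortho to the methylsulfonyl group accepts amino without a step beyond the scatter, whether it replaces (4-chlorophenyl)sulfanyl (a 1.2-fold lower number from compound 3 to compound 4 (0.07 log units; within the scatter)) or cyclohexyl (a 1.4-fold lower number from compound 2 to compound 4 (0.14 log units; within the scatter)). Group size therefore does not sort these compounds: compound 4, with a single heavy atom here, groups with the two larger substituents, while ethyl in compound 1 stands apart (a 3.3-fold higher number from compound 1 to compound 4 (0.52 log units; beyond the scatter)). Nothing measured here explains this. Still open, as far as these compounds go, is whether a methylamino or dimethylamino group, or a propyl chain, would group with amino or with ethyl.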